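Amide substituents on a chalcone scaffold in HUVEC inhibition

The source may hold more compounds than are shown below. What is called first, only, known or untested is meant among the compounds shown, and "the series" means these compounds.

Measured compounds:
compound 1 `COc1cc(/C=C/C(=O)c2cccc(NC(=O)c3c(Cl)cccc3Cl)c2)ccc1O` gives 88% in a functional assay on HUVEC cells (Homo sapiens) for inhibition, tested at 5 ug/mL; on this read-out higher numbers stand for a stronger effect at the one concentration tested and lower numbers for a weaker effect;
compound 2 `COc1cc(/C=C/C(=O)c2cccc(NC(=O)c3ccc(Cl)cc3)c2)ccc1O` gives 42% in this assay;
compound 3 `COc1cc(/C=C/C(=O)c2cccc(N)c2)ccc1O` gives 50% in this assay.

Compound 3, the free amine, stands second highest of the three numbers; compound 2 is nearest and lies within the scatter of it, while compound 1 is furthest and lies beyond the scatter above it. The unmeasured compound 4 `COc1cc(/C=C/C(=O)c2cccc(NC(=O)c3ccc(Cl)cc3Cl)c2)ccc1O` differs from compound 3 by (2,4-dichlorophenyl)carbonyl in place of hydrogen on a nitrogen on an aromatic ring.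

Among the measured compounds shown here, two measured steps bear on this change. The step of a number 38 percentage points lower from compound 1 to compound 3 (beyond the scatter) shows, read backwards, that placing a (2,6-dichlorophenyl)carbonyl on that nitrogen lifts the read-out strongly. The step of a number 8 percentage points higher from compound 2 to compound 3 (within the scatter) shows that a (4-chlorophenyl)carbonyl on the same nitrogen makes no difference beyond the scatter. The (2,4-dichlorophenyl)carbonyl entering in compound 4 shares one chlorine position with each of these two groups, so a rise smaller than that seen for compound 1 but larger than that for compound 2 is expected.

Compound 4 is therefore expected to give 65% in this assay, with a range from 40% to 90%. The expected step is a number 15 percentage points higher from compound 3 to compound 4 (beyond the scatter).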

Compound 4, a percentage reported as inhibition, at one concentration (the size of the read-out at that concentration, not a potency): 51%
Compound 4: the middle estimate sits 14 percentage points above what was measured; the measured number falls inside the stated range.
By their numbers in this assay, from the lowest: compounds 2, 3 and 4 (each within the scatter of the next); then compound 1.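

In this assay the (2,4-dichlorophenyl)carbonyl on this nitrogen gives no difference from the free amine (a number 1 percentage points higher from compound 3 to compound 4 (within the scatter)), and the second chloro on the aromatic ring gives none from the 4-chlorophenyl amide (a number 9 percentage points higher from compound 2 to compound 4 (within the scatter)). Two chlorines on the ring are thus not enough to bring the lift seen with the 2,6-dichlorophenyl group: exchanging it for 2,4-dichlorophenyl on the carbonyl carbon gives a large drop (a number 37 percentage points lower from compound 1 to compound 4 (beyond the scatter)), which leaves compound 1 alone above the other three, so at this position the placing of the chlorines counts, not just their number. Nothing available here accounts for this difference.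

The compounds shown leave open whether a single chlorine, as in a 2-chlorophenyl amide, already carries part of the lift, or whether other groups in the same arrangement, as in a 2,6-difluorophenyl or a 2,6-dimethylphenyl amide, do the same. They also leave open whether the gap between compound 1 and the others holds at other concentrations, since each number stands for a single tested concentration.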